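This account rests on a few compounds, and the source may have more. Where it says the series, first, only, none or still open, it means among the compounds named here.

Measured compounds:
compound 1 `CC(C)=CCOc1cc(=O)n(CCCO)c2c1CC(CC=C(C)C)C(C)(C)C2` — 7.5%
compound 2 `COc1ccc(C(=O)NCCCOc2cc(=O)n(CCCO)c3c2CC(CC=C(C)C)C(C)(C)C3)cc1` — 2.5%
compound 3 `CC(C)=CCC/C(C)=C/CC1Cc2c(OCC=C(C)C)cc(=O)n(CCCO)c2CC1(C)C` — 15.9%

In a functional assay on PANC-1 cells (Homo sapiens) for inhibition, read by MTT assay, with a stated time of 24 h, tested at 10 uM (on this read-out higher numbers stand for more inhibition at the one concentration tested (going by the name of the read-out) and lower numbers for less inhibition), compound 3 stands highest of the three numbers; compound 1 lies within the scatter of it, compound 2 beyond it. Among the compounds with values here, the one single-point step, a number 8.4 percentage points higher from compound 1 to compound 3 (within the scatter), is within the scatter. Compound 4 `CC(C)=CCC/C(C)=C/CC1Cc2c(OC(=O)Nc3ccc(F)c(F)c3)cc(=O)n(CCCO)c2CC1(C)C` differs from compound 3 by (3,4-difluorophenyl)carbamoyl in place of 3-methylbut-2-en-1-yl on an oxygen on an aromatic ring. Within the data shown here, no measured step touches a change on this oxygen; compound 1 and compound 2 carry different chains there and both give low numbers, but no single-point step joins them. No step beyond the scatter is therefore expected in this assay for compound 4, with a number 6.9 percentage points lower from compound 3 to compound 4 (within the scatter) the expected step. Compound 4 is estimated at 9%, in the range 0% to 22%.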

Compound 4, a percentage reported as inhibition, at one concentration (the size of the read-out at that concentration, not a potency): 4.8%
Estimate against measurement, compound 4: 4.2 percentage points above; measured number inside the range.
By their numbers in this assay, from the lowest: compounds 2, 4, 1 and 3 (each within the scatter of the next, the first and the last beyond it).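

Within the data shown here, on the oxygen on an aromatic ring, a change now gives a readable step in this assay: a number 11.1 percentage points lower from compound 3 to compound 4 (beyond the scatter), the first step beyond the scatter and the first to touch this oxygen. Replacing 3-methylbut-2-en-1-yl with (3,4-difluorophenyl)carbamoyl therefore lowers the number on the compound 3 background, though the step is modest. No available evidence bears on the reason for this step.

One pair cannot separate the contribution of the carbamoyl link from that of the fluorines. Going by these compounds, how plain phenylcarbamoyl, or a chain ending in an amine or a carboxylic acid, would read on this oxygen remains open.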